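Piperazine nitrogen substituent on the shared core

The source may report more compounds than this note shows. Statements on the series, on what has been measured and on what is new or still open speak of the compounds shown alone.

Measured compounds in a functional assay on DU-145 cells (Homo sapiens) for cytotoxicity, read by sulforhodamine B assay, with a stated time of 48 h; a higher number here means a weaker inhibitor of growth, a lower number a stronger inhibitor of growth:
- compound 1, `N#Cc1ccc(Nc2nc(Oc3ccnc4ccccc34)nc(N3CCN(c4ccccc4Cl)CC3)n2)cc1C(F)(F)F`, reports only a limit: > 100000 nM
- compound 2, `N#Cc1ccc(Nc2nc(Oc3ccnc4ccccc34)nc(N3CCN(c4cccc(C(F)(F)F)c4)CC3)n2)cc1C(F)(F)F`, gives 74100 nM

Going by the values given here, compound 2 holds the only number so far in this assay; the one further value is a limit. Among the compounds with values here, the step of an at least 1.3-fold lower number from compound 1 to compound 2 (0.13 log units; that floor lies within the scatter) is the single measured step, and it is anchored by the limit of > 100000 nM in this assay, at which 1 of the 2 values shown sits, so its true size is not known.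

Compound 3, `CCN1CCN(c2nc(Nc3ccc(C#N)c(C(F)(F)F)c3)nc(Oc3ccnc4ccccc34)n2)CC1`, differs from compound 2 by ethyl in place of 3-(trifluoromethyl)phenyl on an amine nitrogen in a ring. Within the data shown here, no measured step swaps an aromatic group on that ring nitrogen for a chain, so the aryl-to-aryl step from compound 1 to compound 2 bears on it only loosely. With both measured values weak, no step beyond the scatter is expected in this assay, and a limit is a real possibility. Compound 3 is therefore estimated at 90000 nM, in the range 20000 nM to 300000 nM, meaning an expected step of a 1.2-fold higher number from compound 2 to compound 3 (0.08 log units; within the scatter).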

Compound 3, concentration for total growth inhibition: > 100000 nM
Compound 3 ended at the assay's limit; the forecaster's own chance of this, stated with the estimate: 55%; middle value at least 1.1-fold (0.04 log units) from the limit.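

Ethyl in place of 3-(trifluoromethyl)phenyl on the amine nitrogen in the ring gives an at least 1.3-fold higher number from compound 2 to compound 3 (0.13 log units; that floor lies within the scatter), so swapping an aromatic group for a chain at this position shows no gain in growth inhibition in this assay. The step from compound 1 to compound 3 joins two limits and cannot be read. Compound 2 remains the only compound with a number, and the position now has one chain and two aromatic groups that all leave the read-out weak or unreadable: the limit of > 100000 nM in this assay, at which 2 of the 3 values shown sit.

Still open, going by these compounds, is whether a benzyl group, a longer chain ending in an amine, or a carboxylic acid on this ring nitrogen would give a number clearly beyond the scatter from that of compound 2. Also open, on these data alone, is how far any group here can move the read-out, as all three compounds share the same core.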